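The compounds below may be only part of what the source reports. "The series", "measured", "known", "first", "only" and "open" are said of these compounds alone.

Measured in a functional assay on Hs578 cells (Homo sapiens) for cytotoxicity, read by MTT assay, with a stated time of 24 h; on this read-out lower numbers stand for stronger inhibition and higher numbers for weaker inhibition:
- Compound 1 `Cc1ccc(Cl)cc1S(=O)(=O)Nc1ccc(Cl)c(Cl)c1`: 54000 nM
- Compound 2 `Cc1ccc(NS(=O)(=O)c2cc(Cl)sc2Cl)cc1`: 40200 nM

In this assay, compound 2 stands level with compound 1, since their two values lie within the usual scatter. Compound 3 `Cc1ccc(N(SC(Cl)(Cl)Cl)S(=O)(=O)c2cc(Cl)sc2Cl)cc1` carries (trichloromethyl)sulfanyl in place of hydrogen on a sulfonamide nitrogen. For the measured compounds named here, no measured pair shows what such a change does, so the expectation is tentative. A clear move towards stronger inhibition is expected, with an estimated step of a 5.0-fold lower number from compound 2 to compound 3 (0.70 log units; beyond the scatter). The estimated value for compound 3 is 8000 nM, with an expected range of 1500 nM to 30000 nM.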

Compound 3, half-maximal inhibitory concentration: 24900 nM
For compound 3 the middle estimate is 3.1-fold (0.49 log units) below the measured one; the range from low to high includes it.
By their numbers in this assay, from the lowest: compounds 3, 2 and 1 (each within the scatter of the next, the first and the last beyond it).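

In this assay, (trichloromethyl)sulfanyl in place of hydrogen on a sulfonamide nitrogen gives a 1.6-fold lower number from compound 2 to compound 3 (0.21 log units; within the scatter). This position therefore accepts a much larger group without a clear shift in the read-out, and the hydrogen on that nitrogen is not required for the activity seen here. Nothing available explains this result. As far as these compounds go, whether a simple methyl or acetyl group on that nitrogen would also leave the read-out level remains open. So does whether the same change would behave alike on the core of compound 1.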